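This account rests on a few compounds, and the source may have more. Where it says the series, first, only, none or still open, it means among the compounds named here.

Series notes. Compound 1 `C[C@@H](O)[C@H]1C(=O)N2C(C(=O)OCOC(=O)OC3CCCCC3)=C(S[C@@H]3CN[C@H](C(=O)Nc4cccc(C(=O)O)c4)C3)[C@H](C)[C@H]12` and compound 2 `COC(=O)OCOC(=O)C1=C(S[C@@H]2CN[C@H](C(=O)Nc3cccc(C(=O)O)c3)C2)[C@H](C)[C@@H]2[C@@H]([C@@H](C)O)C(=O)N12` share one core and differ in one place. In an ADME assay for metabolic stability, read by LC-MS, with a stated time of 3 h, at pH 6.5, tested at 50 uM (on this read-out higher numbers stand for a more stable compound and lower numbers for a less stable compound), compound 1 gives > 95%, which is a limit of the assay and not a number. In this assay compound 2 gives > 95%, again a limit. The step that the two limits leave unreadable from compound 1 to compound 2 therefore has no readable size because of the limit of > 95% in this assay, at which 2 of the 2 values shown sit. Compound 3 `C[C@@H](O)[C@H]1C(=O)N2C(C(=O)OCOC(=O)OC(C)(C)C)=C(S[C@@H]3CN[C@H](C(=O)Nc4cccc(C(=O)O)c4)C3)[C@H](C)[C@H]12` differs from compound 2 by tert-butyl in place of methyl on an oxygen next to a carbonyl group. For the measured compounds named here, the only measured step at this oxygen, cyclohexyl to methyl, left no readable size, so no measured size for any change at this place is available. Compound 3 is expected to remain at the same limit in this assay. The step that the limit leaves unreadable from compound 2 to compound 3 is estimated as none beyond the scatter. For compound 3 the estimate in this assay is 96%, within 88% to 100%, most likely reported once more as a limit.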

Compound 3, percent of the compound remaining: > 95%
Compound 3 was reported as a limit (the forecaster's own chance of this, stated with the estimate: 85%); the middle value is on the limit's open side.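

In this assay compound 3 sits at the same limit as compound 1 and compound 2, so no step among these compounds can be read: the limit of > 95% in this assay, at which 3 of the 3 values shown sit.

The compounds shown leave open whether cyclohexyl, methyl and tert-butyl on this oxygen differ at all in this assay.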